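A few compounds are considered here, and "the series" means these few. Any claim that something is new, unique, unknown or untested is made for them only; others in the source may bear on it.

Compounds measured so far:
compound 1, `COc1ccccc1N1CCN(CCCCCCOc2ccc(C(=O)Nc3ccccc3OCCCC(=O)O)cc2)CC1` – 9500 nM
compound 2, `COc1ccccc1N1CCN(CCC(Oc2ccc(C(=O)Nc3ccccc3OCCCC(=O)O)cc2)c2ccc(C)cc2)CC1` – 67 nM

In an assay on isolated protein for inhibition of steroid 5-alpha-reductase (Rattus norvegicus) (on this read-out lower numbers stand for stronger inhibition and higher numbers for weaker inhibition), compound 2 stands at the lowest of the two numbers. Compound 1 gives 9500 nM, a gap beyond the scatter. Compound 3, `COc1ccccc1N1CCN(CCC(Oc2ccc(C(=O)Nc3ccccc3OCCCC(=O)O)cc2)c2ccc(Br)cc2)CC1`, differs from compound 2 by bromo in place of methyl on an aromatic carbon. For the measured compounds named here, no measured pair shows this change, so nothing measured sets its size. The step expected in this assay is a 1.1-fold lower number from compound 2 to compound 3 (0.05 log units; within the scatter), none beyond the scatter in either direction. Compound 3 is therefore estimated to give 60 nM, between 25 nM and 150 nM.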

Compound 3, half-maximal inhibitory concentration: 210 nM
Beside the measured number, compound 3's estimate is 3.5-fold (0.54 log units) below it; measured number outside the range, above it.
By their numbers in this assay, from the lowest: compound 2; then compound 3; then compound 1.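

In this assay, exchanging 4-methylphenyl for 4-bromophenyl gives a 3.1-fold higher number from compound 2 to compound 3 (0.50 log units; beyond the scatter), so this place on the ring is sensitive to which group it carries, even though one heavy atom replaces another and neither group has a hydrogen-bond donor or acceptor. The change is modest, yet it favours methyl over bromo. Nothing measured here explains the difference. On these data alone, what remains open is how a chloro or methoxy group, or a phenyl ring with no group at this place, would compare with methyl and bromo.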